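The source may hold more compounds than are shown below. What is called first, only, known or untested is meant among the compounds shown, and "the series" means these compounds.

In a toxicity assay on THP-1 cells (Homo sapiens) for inhibition (on this read-out lower numbers stand for higher toxicity in this test and higher numbers for lower toxicity in this test), three amides on a shared core have been tested. Compound 1 (`COc1ccc(-c2cnc(NC(=O)c3ccccc3C)n2C)cc1`), with 2-methylphenyl on the carbonyl carbon, gives > 100000 nM, which is a limit and not a number. Compound 2 (`COc1ccc(-c2cnc(NC(=O)C3CCCCC3)n2C)cc1`), with cyclohexyl there, gives > 100000 nM, again a limit. Compound 3 (`COc1ccc(-c2cnc(NC(=O)C3CCOCC3)n2C)cc1`), with oxan-4-yl, gives > 100000 nM, also a limit. Compound 3 therefore has no number of its own, and the series shows only (the limit of > 100000 nM in this assay, at which 3 of the 3 values shown sit).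

Compound 4 (`COc1ccc(-c2cnc(NC(=O)c3ccc(Cl)cc3)n2C)cc1`) carries 4-chlorophenyl in place of oxan-4-yl on a carbonyl carbon. The measured steps that bear on this change sit at the same place. Oxan-4-yl for 2-methylphenyl is a step that the two limits leave unreadable from compound 1 to compound 3, cyclohexyl for 2-methylphenyl is a step that the two limits leave unreadable from compound 1 to compound 2, and oxan-4-yl for cyclohexyl is a step that the two limits leave unreadable from compound 2 to compound 3. None of them has a readable size. Among the measured compounds shown here, compound 1, the one tested compound with an aromatic ring of carbon only at this place, stands at the limit of > 100000 nM. No step beyond the scatter is therefore expected in this assay, and the expected change is a number no higher from compound 3 to compound 4 (the limit leaves the size open). Compound 4 is estimated at 100000 nM, within an expected range from 35000 nM to 200000 nM.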

Compound 4, half-maximal cytotoxic concentration: > 100000 nM
Compound 4: a limit, no number; the forecaster's own chance of this, stated with the estimate: 75%; the middle value sits exactly at the limit.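

In this assay, among the compounds shown here, compound 4 gives only a limit, so no step from compound 1, compound 2 or compound 3 to compound 4 can be read, and the series shows only this: the limit of > 100000 nM in this assay, at which 4 of the 4 values shown sit. The compounds shown leave open what actual number any of these four amides would give, and whether changing the group on the carbonyl carbon alters toxicity at all.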